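The source may report more compounds than this note shows. Statements on the series, on what has been measured and on what is new or still open speak of the compounds shown alone.

Compound 1 `COc1cc(OC)c2sc(-c3ccc(N/C=C\C(=O)c4ccc(OC)c(O)c4)c(C)c3)nc2c1`: 3100 nM
Compound 2 `COc1ccc(C(=O)/C=C\Nc2ccc(-c3nc4cc(OC)c(OC)c(OC)c4s3)cc2C)cc1O`: 12400 nM

In a functional assay on MDA-MB-231 cells (Homo sapiens) for antiproliferative activity, read by sulforhodamine B assay, with a stated time of 48 h (on this read-out higher numbers stand for weaker inhibition and lower numbers for stronger inhibition), compound 1 gives 3100 nM, the lower of the two numbers. Compound 3 `COc1cc(OC)c2sc(-c3ccc(N/C=C\C(=O)c4ccc(OC)c([N+](=O)[O-])c4)c(C)c3)nc2c1` carries nitro in place of hydroxy on an aromatic carbon, ortho to a methoxy group: nitro in place of hydroxy on an aromatic carbon. Among the measured compounds shown here, the only measured step, a 4.0-fold higher number from compound 1 to compound 2 (0.60 log units; beyond the scatter), is methoxy in place of hydrogen at another place, so it bears on this change only indirectly. For the measured compounds named here, no measured compound shows a replacement of the hydroxy. A modest step towards a higher number in this assay is therefore expected, of similar size to that step. The expected step is a 1.9-fold higher number from compound 1 to compound 3 (0.29 log units; within the scatter). For compound 3 the estimated value is 6000 nM, with an expected range from 1800 nM to 20000 nM.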

Compound 3, half-maximal inhibitory concentration: 10800 nM
The estimate for compound 3 lay 1.8-fold (0.26 log units) below the measured number; low and high end bracket the measured number.
By their numbers in this assay, from the lowest: compound 1; then compounds 3 and 2 (each within the scatter of the next).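

Exchanging 3-hydroxy-4-methoxyphenyl for 4-methoxy-3-nitrophenyl gives a 3.5-fold higher number from compound 1 to compound 3 (0.54 log units; beyond the scatter) in this assay. Among the compounds shown here, this is the first measured change at this place, ortho to a methoxy group, and it shows that inhibition weakens when nitro, which has no hydrogen-bond donor, stands in place of the hydroxy. No measured evidence explains this result. The compounds shown leave open how an amine, a carboxylic acid or a plain hydrogen would fare at this place, and whether the hydroxy itself matters or nitro alone weakens inhibition.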